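Piperidin-1-yl for Dimethylamino on a Second Core

This account rests on a few compounds, and the source may have more. Where it says the series, first, only, none or still open, it means among the compounds named here.

Compound 1 `COc1ccc2cc(C(=O)CCN(C)C)c(=O)oc2c1` and compound 2 `COc1ccc2cc(C(=O)CCN3CCCCC3)c(=O)oc2c1` share one core, while compound 3 `Cc1cc(O)cc2oc(=O)c(C(=O)CCN(C)C)cc12` and compound 4 `Cc1cc(O)cc2oc(=O)c(C(=O)CCN3CCCCC3)cc12` share another. Compound 3 has the same atoms as compound 1, joined differently, and the difference between the two cores is not broken down here. In an assay on cells for inhibition of Amine oxidase [flavin-containing] A (Homo sapiens), read by fluorescence, spectrophotometry and Amplex Red, with stated times of 60 min and 30 min (a lower number here means a stronger inhibitor, a higher number a weaker inhibitor), compound 1 gives 7630 nM. In this assay compound 2 gives 12200 nM. The change between them, (piperidin-1-yl in place of dimethylamino on a saturated chain carbon, two bonds along the chain from a carbonyl carbon), made a step of a 1.6-fold higher number from compound 1 to compound 2 (0.20 log units; within the scatter). For compound 3 this assay reports only a limit, > 200000 nM, which is the limit of > 200000 nM in this assay, at which 1 of the 3 values shown sits. The same change is now made from compound 3 to compound 4, (piperidin-1-yl in place of dimethylamino on a saturated chain carbon, two bonds along the chain from a carbonyl carbon), at a place described in the same words. Because the earlier step of a 1.6-fold higher number from compound 1 to compound 2 (0.20 log units; within the scatter) lay within the scatter, the step from compound 3 to compound 4 is expected to be similarly small, a step that the limit leaves unreadable from compound 3 to compound 4. Compound 3 already sits at the limit, and compound 4 is expected to return a limit as well. Compound 4 is estimated at 300000 nM, with a range from 150000 nM to 800000 nM.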

Compound 4, half-maximal inhibitory concentration: 136000 nM
For compound 4 the middle estimate is 2.2-fold (0.34 log units) above the measured one; the whole stated range lies above it.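

For compound 3, this assay reports only a limit, > 200000 nM. Against that limit, the change from dimethylamino to piperidin-1-yl gives an at least 1.4-fold lower number from compound 3 to compound 4 (0.16 log units; that floor lies within the scatter), which is a floor for the step and not its size. Set beside the earlier step, the two cores read as follows: the same change on two cores in this assay, a 1.6-fold higher number (0.20 log units; within the scatter) from compound 1 to compound 2 and an at least 1.4-fold lower number (0.16 log units; that floor lies within the scatter) from compound 3 to compound 4; the limit leaves it open whether they differ

This pair shows that the change has been followed on both cores and that compound 4 returns a measured number where compound 3 has only a limit, but it does not show whether the change carries from one core to the other with the same size.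

The compounds shown leave open how other amines on the same chain carbon, such as morpholine or a primary amine, would read on either core. They also leave open what a longer chain between the carbonyl and the amine would do, and whether a measured value for the dimethylamino compound on the second core would settle the comparison.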